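Carboxymethyl in Place of the Amide Side Chain

This account rests on a few compounds, and the source may have more. Where it says the series, first, only, none or still open, it means among the compounds named here.

Measured compounds and their values:
compound 1 `COc1ccc(-c2nc(CNC(=O)CSc3ccccc3)sc2-c2ccc(OC)cc2)cc1` — < 100 nM
compound 2 `COc1ccc(-c2nc(C(=O)N3CCCCC3CCO)sc2-c2ccc(OC)cc2)cc1` — 45 nM
compound 3 `COc1ccc(-c2nc(C(=O)N3CCN(C(=O)NC(C)C)CC3)sc2-c2ccc(OC)cc2)cc1` — > 1000 nM

Three compounds built on the shared core of compound 1 have been tested in a functional assay with Oryctolagus cuniculus as the target; on this read-out lower numbers stand for stronger inhibition and higher numbers for weaker inhibition. For compound 1 the result is only a limit, < 100 nM, so its true place is not pinned down by a number. Compound 2 gives 45 nM. For compound 3 the result is again only a limit, > 1000 nM. Compound 1 therefore sits at one of the two limits of this small set (the limit of < 100 nM in this assay, at which 1 of the 3 values shown sits), and nothing more can be said about how it stands against compound 2 or compound 3. For the measured compounds named here, no two measured compounds differ in a single place, so no measured step exists to lean on.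

Compound 4 `COc1ccc(-c2nc(CCC(=O)O)sc2-c2ccc(OC)cc2)cc1` differs from compound 1 in one place: carboxymethyl in place of (((phenylsulfanyl)methyl)carbonyl)amino on a saturated chain carbon bound to an aromatic carbon. Without a measured step for guidance, the exchange of a large neutral side chain for a short acidic one in a whole-organism read-out is expected to weaken inhibition, and the step of an at least 6.0-fold higher number from compound 1 to compound 4 (0.77 log units; beyond the scatter) is the estimate of that loss. Compound 4 is accordingly expected to give 600 nM in this assay, within a range from 100 nM to 4000 nM, with a real chance that only a limit is reported.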

Compound 4, half-maximal inhibitory concentration: < 100 nM
Compound 4 ended at the assay's limit; the forecaster's own chance of this, stated with the estimate: 35%; middle value at least 6.0-fold (0.77 log units) from the limit.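

In this assay compound 4 gives < 100 nM, a limit and not a number. For the compounds shown here, compound 1 also gives only a limit, < 100 nM, so no step between the two can be read. The compounds shown leave open whether carboxymethyl in place of (((phenylsulfanyl)methyl)carbonyl)amino strengthens, weakens or leaves unchanged the inhibition.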